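Hydroxyphenyl Replaces Isopropyl on the Ring Nitrogen

The source may report more compounds than this note shows. Statements on the series, on what has been measured and on what is new or still open speak of the compounds shown alone.

Compound 1 `CCC/N=C1\S/C(=C\c2ccc(O)c(Cl)c2)C(=O)N1C1CC1` and compound 2 `CCC/N=C1\S/C(=C\c2ccc(O)c(Cl)c2)C(=O)N1C(C)C` share one core and differ only on an amide-type nitrogen in a ring. In a physicochemical assay for lipophilicity, read by HPLC, at pH 7.4 (a lower number here means a more polar compound, a higher number a more lipophilic compound), compound 1 gives 3.4. For compound 2 this assay reports only a limit, > 4.3, so its position is known as a range rather than a number (the limit of > 4.3 in this assay, at which 1 of the 2 values shown sits). Among the measured compounds shown here, the one measured step is a number at least 0.90 log units higher from compound 1 to compound 2 (beyond the scatter). Compound 3 `CCC/N=C1\S/C(=C\c2ccc(O)c(Cl)c2)C(=O)N1c1ccccc1O` carries 2-hydroxyphenyl in place of isopropyl on an amide-type nitrogen in a ring. For the measured compounds named here, no measured step covers this kind of exchange, so the expectation rests on where compound 2 already stands. Compound 3 is expected to give 4.6, within 4 to 5.2. The estimated step is a step that the limit leaves unreadable from compound 2 to compound 3.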

Compound 3, distribution coefficient: 2.7
Compound 3: middle estimate off by 1.90 log units, on the high side; the whole stated range lies above it.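

In this assay, the change to 2-hydroxyphenyl on this nitrogen gives a number at least 1.60 log units lower from compound 2 to compound 3 (beyond the scatter), even though the entering group has more heavy atoms than isopropyl. Against cyclopropyl, the same group gives a number 0.70 log units lower from compound 1 to compound 3 (beyond the scatter), so compound 3 reads lowest of the three. The first of these steps is only a bound, as compound 2 is known by a limit: the limit of > 4.3 in this assay, at which 1 of the 3 values shown sits.

The compounds shown leave open whether the aromatic ring or its hydroxyl sets this reading. A plain phenyl or a 2-methoxyphenyl on this nitrogen would separate the two.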